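This account rests on a few compounds, and the source may have more. Where it says the series, first, only, none or still open, it means among the compounds named here.

Working notes on the series. Two compounds of the shared core have numbers in a functional assay on CHO-K1 cells for antagonist activity at melanin-concentrating hormone receptor 1 (Homo sapiens), read by inositol phosphate accumulation, with stated times of 10 min and 45 min; a lower number here means a stronger inhibitor, a higher number a weaker inhibitor: compound 1 `Cc1nc(NCCNC(=O)C2CC2)nc2ccc(NC(=O)/C=C/c3ccc(OC(F)(F)F)cc3)cc12` gives 23 nM, and compound 2 `COCC(=O)NC1CCN(c2nc(C)c3cc(NC(=O)/C=C/c4ccc(OC(F)(F)F)cc4)ccc3n2)CC1` gives 14 nM. The step of a 1.6-fold lower number from compound 1 to compound 2 (0.22 log units; within the scatter) is the only measured one, and on the numbers shown compound 2 stands lowest of two, with compound 1 its nearest neighbour inside the scatter. The next compound, compound 3 `Cc1nc(N2CCC(N3CCN(C)C3=O)CC2)nc2ccc(NC(=O)/C=C/c3ccc(OC(F)(F)F)cc3)cc12`, keeps the piperidinyl group introduced in compound 2 and alters only what sits on it: 3-methyl-2-oxoimidazolidin-1-yl in place of ((methoxymethyl)carbonyl)amino on a saturated ring carbon. For the measured compounds named here, the one measured step that bears on this, a 1.6-fold lower number from compound 1 to compound 2 (0.22 log units; within the scatter), touched the same region of the molecule and stayed within the scatter, so the region appears tolerant of quite different groups there; that is a thin basis, resting on one pair. For compound 3, accordingly, no step beyond the scatter is expected in this assay, in either direction, with the change no change at the digits printed from compound 2 to compound 3 (within the scatter) taken as the expected outcome. Compound 3 is estimated at 14 nM, with a range from 5 nM to 40 nM.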

Compound 3, half-maximal inhibitory concentration: 21 nM
Compound 3: middle estimate off by 1.5-fold (0.18 log units), on the low side; low and high end bracket the measured number.
By their numbers in this assay, from the lowest: compounds 2, 3 and 1 (each within the scatter of the next).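

In this assay, exchanging the open-chain ((methoxymethyl)carbonyl)amino group for 3-methyl-2-oxoimidazolidin-1-yl gives a 1.5-fold higher number from compound 2 to compound 3 (0.18 log units; within the scatter) while the rest of the molecule stays fixed, so this pair isolates the group on the saturated ring carbon in a way that the earlier step, which replaced the whole substituent on the aromatic carbon, could not. Compound 1 and compound 2 both carry an amide hydrogen, whereas the group entering in compound 3 has 0 hydrogen-bond donors and a five-membered non-aromatic ring, and neither difference moves the number beyond the scatter in this single pair. No supporting data are available to account for this result, and the pair gives only the size of the step. On these data alone, whether the same saturated ring carbon accepts a dimethylamino group, a carboxylic acid or a longer chain with a number in this range remains open. As far as these compounds go, it is also open whether a ring carbon bearing only hydrogen would stay within the scatter of compound 2 and compound 3, which would show how much the group at this place contributes at all.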